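This account rests on a few compounds, and the source may have more. Where it says the series, first, only, none or still open, it means among the compounds named here.

Measured in an assay on NIH3T3 cells with melatonin receptor type 1A (Homo sapiens) as the target; on this read-out higher numbers stand for weaker inhibition and lower numbers for stronger inhibition:
compound 1 `CCCC1Nc2cccc([C@@H]3C[C@H]3CNC(=O)C(C)C)c2O1` gives 4.9 nM
compound 2 `CCCC1Nc2cccc([C@@H]3C[C@H]3CNC(=O)C3CC3)c2O1` gives 0.18 nM

Compound 1 stands highest of the two numbers in this assay. Within the data shown here, the one measured step, a 27-fold lower number from compound 1 to compound 2 (1.43 log units; beyond the scatter), alters the group on the carbonyl carbon and says nothing about the saturated ring carbon. Compound 3 `CC(C)C(=O)NC[C@@H]1C[C@H]1c1cccc2c1OC(C(C)C)N2` is compound 1 with isopropyl in place of propyl on a saturated ring carbon. Among the measured compounds shown here, no measured step touches this place, so there is no direct precedent; the expected change is small, within the scatter, as no change at the digits printed from compound 1 to compound 3 (within the scatter). Compound 3 is therefore estimated at 4.9 nM in this assay, with a range from 1.5 nM to 16 nM.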

Compound 3, inhibition constant: 1.3 nM
Beside the measured number, compound 3's estimate is 3.8-fold (0.58 log units) above it, and the stated range ends above it.
By their numbers in this assay, from the lowest: compound 2; then compound 3; then compound 1.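

In this assay the saturated ring carbon responds to a swap of two groups with the same count of heavy atoms: isopropyl in place of propyl gives a 3.8-fold lower number from compound 1 to compound 3 (0.58 log units; beyond the scatter) as a modest step. The group on the carbonyl carbon is therefore not the only place in this series where a single change moves the number. Nothing on hand gives a cause for this step.

From the compounds shown here alone, whether a longer chain such as butyl or an amine at this ring carbon would lower the number further remains open. Also open, going by these compounds, is whether isopropyl would give a similar step alongside the cyclopropyl group of compound 2.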